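A few compounds are considered here, and "the series" means these few. Any claim that something is new, unique, unknown or untested is made for them only; others in the source may bear on it.

Measured so far:
compound 1 `CC(C)c1cccc(C(C)C)c1NC(=O)NS(=O)(=O)N(c1ccccc1)c1ccccc1`, 16000 nM
compound 2 `CCC(C)N(C(=O)NS(=O)(=O)Oc1c(C(C)C)cccc1C(C)C)C(C)CC`, 12000 nM
compound 3 `CCCCN(CCCC)S(=O)(=O)NC(=O)Oc1c(C(C)(C)C)cc(C)cc1C(C)(C)C`, 3200 nM

In an assay on liver for inhibition of sterol O-acyltransferase 1 (Rattus norvegicus), using microsomes (on this read-out lower numbers stand for stronger inhibition and higher numbers for weaker inhibition), compound 2 gives 12000 nM. Compound 1 gives 16000 nM, a number within the scatter of that for compound 2. Compound 3 gives 3200 nM, a lower number than compound 2 and beyond the scatter, so compound 2 sits among the weaker inhibitors of the three.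

Compound 4 `CC(C)c1cccc(C(C)C)c1OS(=O)(=O)NC(=O)Oc1ccc(F)cc1F` has not been measured. Its difference from compound 2 is 2,4-difluorophenoxy in place of bis(sec-butyl)amino on a carbonyl carbon. Among the compounds with values here, no step between measured compounds shares this change, so the direction is open; a step of modest size toward a lower number is expected in this assay, not far beyond the scatter. Compound 4 is expected to give 8000 nM, with a range of 2000 nM to 30000 nM. The step of a 1.5-fold lower number from compound 2 to compound 4 (0.18 log units; within the scatter) is the estimate.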

Compound 4, half-maximal inhibitory concentration: > 50000 nM
Compound 4 was reported as a limit (the forecaster's own chance of this, stated with the estimate: 15%); middle value at least 6.2-fold (0.79 log units) away from the limit.
By their numbers in this assay, from the lowest: compound 3; then compounds 2 and 1 (each within the scatter of the next). At a limit, above all of these: compound 4.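

In this assay compound 4 is reported only as a limit, > 50000 nM. Putting 2,4-difluorophenoxy in place of bis(sec-butyl)amino on a carbonyl carbon gives an at least 4.1-fold higher number from compound 2 to compound 4 (0.61 log units; beyond the scatter), so the group at this position matters in this assay. Within the data shown here, this is the first one-place step, and it reads in one direction only, with its full size unknown.

As far as these compounds go, whether diethylamino or unsubstituted phenoxy at this carbonyl would keep a measurable number stays open. The compounds shown also do not separate the part played by the ring oxygen link from that of the fluorine atoms.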